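The source may report more compounds than this note shows. Statements on the series, on what has been measured and on what is new or still open speak of the compounds shown alone.

Measured so far:
Compound 1, `O=C1[C@@H](NS(=O)(=O)c2cc3ccc(Cl)nc3s2)CCN1Cc1cc2[nH]cccc-2n1`, in an assay on isolated protein for inhibition of coagulation factor X (Oryctolagus cuniculus), tested at 1 uM; on this read-out higher numbers stand for more inhibition at the one concentration tested (going by the name of the read-out) and lower numbers for less inhibition: 23%
Compound 2, `CC(C)(C)c1ccc(S(=O)(=O)N[C@H]2CCN(CCNc3ccncc3)C2=O)cc1`, in this assay: 14%

Compound 2 stands lowest of the two numbers, but its nearest neighbour, compound 1, lies only a little higher, a gap within the usual scatter, so the two cannot be ordered. Compound 3 `CC(C)(C)c1ccc(S(=O)(=O)N[C@H]2CCN(Cc3cc4[nH]cccc-4n3)C2=O)cc1` has not yet been measured. It differs from compound 2 in one place: a group of 9 heavy atoms (7 carbon, 2 nitrogen; one five-membered aromatic ring with 1 hetero atom, one six-membered aromatic ring with 1 hetero atom) in place of a group of 8 heavy atoms (6 carbon, 2 nitrogen; one six-membered aromatic ring with 1 hetero atom), on a saturated chain carbon bound to an amide-type nitrogen in a ring. Within the data shown here, no step between two measured compounds isolates this change, so its effect in this assay is not known from the data. Among the measured compounds shown here, compound 1 carries the same entering group on the same kind of carbon and gives a number of similar size, and nothing among the measured compounds points to a shift beyond the scatter. The expected step is therefore small: a number 6 percentage points higher from compound 2 to compound 3 (within the scatter). Compound 3 is expected to give about 20% in this assay, within a range from 5% to 40%.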

Compound 3, a percentage reported as inhibition, at one concentration (the size of the read-out at that concentration, not a potency): 22%
The estimate for compound 3 lay 2 percentage points below the measured number; low and high end bracket the measured number.
By their numbers in this assay, from the lowest: compounds 2, 3 and 1 (each within the scatter of the next).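

In this assay, replacing the ((pyridin-4-yl)amino)methyl group with the new group on a saturated chain carbon bound to an amide-type nitrogen in a ring gives a number 8 percentage points higher from compound 2 to compound 3 (within the scatter) and so does not separate the two compounds. With that new group held constant, exchanging the group on the sulfonyl sulfur gives a number 1 percentage points lower from compound 1 to compound 3 (within the scatter) and likewise does not separate them, so neither place has yet produced a step beyond the scatter. Nothing available gives a reason for either result.

The compounds shown leave open whether a carboxylic acid or a primary amine at the saturated chain carbon would move the number beyond the scatter. They also leave open whether a longer chain carrying the pyridin-4-yl ring would do so, and a single tested concentration gives no potency for any of the three.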